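The source may report more compounds than this note shows. Statements on the series, on what has been measured and on what is new or still open speak of the compounds shown alone.

Measured compounds:
- compound 1, `CCCn1c(=O)[nH]c2nc(-c3ccc(S(=O)(=O)N4CCN(c5ccc(F)cc5)CC4)cc3)[nH]c2c1=O`, 0.644 nM
- compound 2, `CCCn1c(=O)[nH]c2nc(-c3ccc(S(=O)(=O)N4CCN(c5cccc(Cl)c5)CC4)cc3)[nH]c2c1=O`, 0.342 nM
- compound 3, `CCCn1c(=O)[nH]c2nc(-c3ccc(S(=O)(=O)N4CCN(C(C)c5ccccc5)CC4)cc3)[nH]c2c1=O`, 8.34 nM

In an assay on CHO cells for displacement of a labelled ligand from adenosine receptor A2b (Homo sapiens), read by scintillation counting, with a stated time of 75 min, in the presence of a further agent that is not named here (a lower number here means a stronger inhibitor, a higher number a weaker inhibitor), compound 3 gives the highest number of the three, so it is the weakest inhibitor here: its steps to compound 1 and to compound 2 are both beyond the scatter. The new compound 4, `CCCn1c(=O)[nH]c2nc(-c3ccc(S(=O)(=O)N4CCN(Cc5ccc(Br)cc5)CC4)cc3)[nH]c2c1=O`, differs from compound 3 in one place: 4-bromobenzyl in place of 1-phenylethyl on an amine nitrogen in a ring. The measured steps that bear on this concern the same ring nitrogen. a 13-fold higher number from compound 1 to compound 3 (1.11 log units; beyond the scatter) and a 24-fold higher number from compound 2 to compound 3 (1.39 log units; beyond the scatter) show that swapping an aromatic ring sitting directly on that nitrogen for a 1-phenylethyl group raised the number strongly. Going by the values given here, compound 4 keeps a single carbon between the nitrogen and the ring, as in compound 3, so a return to the numbers of compound 1 or compound 2 is not expected; the loss of the branching methyl and the added bromine are changes with no measured counterpart here. For compound 4 in this assay the number is therefore expected near that of compound 3, perhaps somewhat lower: 4.5 nM, range 1.2 nM to 15 nM. This expectation amounts to a 1.9-fold lower number from compound 3 to compound 4 (0.27 log units; within the scatter).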

Compound 4, inhibition constant: 0.153 nM
For compound 4 the middle estimate is 29-fold (1.47 log units) above the measured one; measured number below the stated range.
By their numbers in this assay, from the lowest: compound 4; then compounds 2 and 1 (each within the scatter of the next); then compound 3.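

In this assay a single carbon between the ring nitrogen and the aromatic ring need not mean a high number: 4-bromobenzyl in place of 1-phenylethyl gives a large drop (a 55-fold lower number from compound 3 to compound 4 (1.74 log units; beyond the scatter)). Compound 4 also has a lower number than the compounds with an aromatic ring directly on that nitrogen (a 2.2-fold lower number from compound 2 to compound 4 (0.35 log units; beyond the scatter); a 4.2-fold lower number from compound 1 to compound 4 (0.62 log units; beyond the scatter)). This position therefore separates two groups that each have 8 heavy atoms and one aromatic ring very sharply.

No measurement shown here explains this gain. The step also removes the branching methyl and adds bromine together, so unsubstituted benzyl, or 4-chlorobenzyl, would be needed to tell these two changes apart.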